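The source may hold more compounds than are shown below. What is called first, only, known or untested is meant among the compounds shown, and "the series" means these compounds.

Measured so far:
- compound 1 `CC/C=C\C[C@H]1C(=O)C=C[C@H]1CC(=O)OCCC`: 23000 nM
- compound 2 `CC/C=C\C[C@H]1C(=O)C=C[C@H]1CC(=O)OCCCC`: 23000 nM
- compound 3 `CC/C=C\C[C@H]1C(=O)C=C[C@H]1CC(=O)OCCCCC`: 25000 nM

All three were measured in a functional assay on RAW264.7 cells (Mus musculus) for inhibition, read by ELISA, with a stated time of 24 h; a lower number here means that less compound is needed, a higher number that more compound is needed for the effect. Compound 2 stands level with compound 1 at the digits shown, and compound 3 lies within the scatter of both. For the measured compounds named here, the series so far is therefore flat.

Next in the series is compound 4 `CC/C=C\C[C@H]1C(=O)C=C[C@H]1CC(=O)Oc1ccccc1`, reached from compound 2 by one change: phenyl in place of butyl on an oxygen next to a carbonyl group. In words, this is phenyl in place of butyl on an oxygen next to a carbonyl group.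

Going by the values given here, three measured steps bear on this position, all of them changes to the saturated chain: no change at the digits printed from compound 1 to compound 2 (within the scatter), a 1.1-fold higher number from compound 1 to compound 3 (0.04 log units; within the scatter) and a 1.1-fold higher number from compound 2 to compound 3 (0.04 log units; within the scatter). Each lies within the scatter, so extending the chain has shown no effect on the numbers in this assay. Among the compounds with values here, none of these steps introduces a ring, however, and no measured compound carries an aromatic group at this place. The steps therefore offer only indirect guidance, and the range has to stay wide.

No step beyond the scatter is expected, and no direction is favoured with any confidence. The expected change is a 1.2-fold lower number from compound 2 to compound 4 (0.06 log units; within the scatter). For compound 4 the estimated value is 20000 nM, with an expected range from 7000 nM to 50000 nM.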

Compound 4, half-maximal effective concentration: 33000 nM
The estimate for compound 4 lay 1.7-fold (0.22 log units) below the measured number; measured number inside the range.
By their numbers in this assay, from the lowest: compounds 1, 2, 3 and 4 (each within the scatter of the next).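

In this assay this position now has a direct reading for an aromatic ring: phenyl in place of butyl gives a 1.4-fold higher number from compound 2 to compound 4 (0.16 log units; within the scatter) and phenyl in place of pentyl gives a 1.3-fold higher number from compound 3 to compound 4 (0.12 log units; within the scatter) while phenyl in place of propyl gives a 1.4-fold higher number from compound 1 to compound 4 (0.16 log units; within the scatter). All three steps lie within the scatter, so the flat picture seen across propyl, butyl and pentyl on this oxygen next to a carbonyl group now extends to phenyl, and one six-membered aromatic ring of carbon only does not separate compound 4 from the saturated chains. No accompanying measurement bears on why these four numbers sit together.

Still open, going by these compounds, is whether any group on this oxygen moves the number beyond the scatter, for instance benzyl, a much longer chain, or a phenyl ring carrying an amine or a carboxylic acid. All four compounds share the core of compound 1 and differ only at this place, so the effect of a change elsewhere on the core remains unread.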